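The source may hold more compounds than are shown below. What is called first, only, known or untested is meant among the compounds shown, and "the series" means these compounds.

Working notes on the series. The shared core of compound 1 `COc1ccccc1-c1ccc(NC(=O)NCCCCN2CCCCC2)cc1` carries a methoxy on the distal ring; in a physicochemical assay for solubility, at pH 7.4 (a higher number here means a more soluble compound, a lower number a less soluble compound), compound 1 gives 114000 nM. Compound 2 `O=C(NCCCCN1CCCCC1)Nc1ccc(-c2ccc(F)nc2)nc1` gives 205000 nM in this assay, and compound 3 `O=C(NCCCCN1CCCCC1)Nc1ccc(-c2ccccc2)nc1` gives 193000 nM. On these three numbers compound 1 stands lowest, nearest to compound 3 and furthest from compound 2, but both gaps are within the scatter, so no order among the three can be read. Among the compounds with values here, the one step between measured neighbours, phenyl in place of 6-fluoropyridin-3-yl on an aromatic carbon, gave a 1.1-fold lower number from compound 2 to compound 3 (0.03 log units; within the scatter).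

Compound 4 `O=C(NCCCCN1CCCCC1)Nc1ccc(-c2ccccc2F)cc1` differs from compound 1 as follows: fluoro in place of methoxy on an aromatic carbon. Within the data shown here, no measured step exchanges a methoxy for a fluoro, and the change on the distal ring of compound 2 to compound 3, which also removes a fluorine, stayed within the scatter. With the three measured numbers all within the scatter of one another, no step beyond the scatter in this assay is expected; the step from compound 1 to compound 4 is estimated at a 1.1-fold higher number from compound 1 to compound 4 (0.06 log units; within the scatter). For compound 4 the expected value in this assay is 130000 nM, with a range of 55000 nM to 280000 nM.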

Compound 4, solubility: 95000 nM
For compound 4 the middle estimate is 1.4-fold (0.14 log units) above the measured one, within the range that was stated.
By their numbers in this assay, from the lowest: compounds 4, 1, 3 and 2 (each within the scatter of the next, the first and the last beyond it).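

Within the data shown here, at this position, on an aromatic carbon ortho to a large group, fluoro in place of methoxy reads as a 1.2-fold lower number from compound 1 to compound 4 (0.08 log units; within the scatter) in this assay, and this is the first step measured here. The 2-methoxyphenyl to 2-fluorophenyl exchange also removes a hydrogen-bond acceptor, yet it leaves the two compounds without a readable separation in this assay. No measurement at hand bears on the reason for this result.

Going by these compounds, whether an amine, a carboxylic acid or a longer chain such as ethoxy at this position would give a step beyond the scatter in this assay remains open. Also open, on these data alone, is whether fluoro in place of methoxy would read the same way on the core of compound 3.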